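A few compounds are considered here, and "the series" means these few. Any claim that something is new, unique, unknown or untested is made for them only; others in the source may bear on it.

Measured in an ADME assay on MT4 cells (Homo sapiens) for cytotoxicity, read by MTT assay; on this read-out higher numbers stand for lower toxicity in this test and lower numbers for higher toxicity in this test:
- compound 1 (`Cc1ccc(N(C(=O)c2ccc([N+](=O)[O-])cc2)C(=S)OCCN2C(=O)c3ccccc3C2=O)cc1`): 58000 nM
- compound 2 (`Cc1cc(C(=O)N(C(=S)OCCN2C(=O)c3ccccc3C2=O)c2ccc(Cl)cc2)ccc1Br`): 18000 nM
- compound 3 (`Cc1ccc(N(C(=O)c2cc(F)cc(F)c2)C(=S)OCCN2C(=O)c3ccccc3C2=O)cc1`): 54000 nM

Compound 3, at 54000 nM, stands within the scatter of compound 1, while compound 2, at 18000 nM, has a lower number, and that gap lies beyond the scatter. Compound 4 (`Cc1ccc(N(C(=O)c2ccc(Br)c(C)c2)C(=S)OCCN2C(=O)c3ccccc3C2=O)cc1`) departs from compound 3 in one place: 4-bromo-3-methylphenyl in place of 3,5-difluorophenyl on a carbonyl carbon. Going by the values given here, the one measured step at this place, a 1.1-fold lower number from compound 1 to compound 3 (0.03 log units; within the scatter), exchanged a different pair of groups and left the number within the scatter, so it argues for a small effect. Against that, compound 2 carries the same 4-bromo-3-methylphenyl on a carbonyl carbon and reads 18000 nM, although it also differs from compound 4 elsewhere in the structure. A modest move towards a lower number is therefore expected in this assay, close to the scatter rather than clearly beyond it. The expected change is a 1.8-fold lower number from compound 3 to compound 4 (0.26 log units; within the scatter). For compound 4 the estimated value is 30000 nM, with an expected range of 14000 nM to 62000 nM.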

Compound 4, half-maximal cytotoxic concentration: > 100000 nM
Compound 4 gave a limit, no number; the forecaster's own chance of this, stated with the estimate: 5%; middle value at least 3.3-fold (0.52 log units) from the limit.
By their numbers in this assay, from the lowest: compound 2; then compounds 3 and 1 (each within the scatter of the next). At a limit, above all of these: compound 4.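

In this assay compound 4 gives a limit of the assay and not a number: the limit of > 100000 nM in this assay, at which 1 of the 4 values shown sits. The clearest new information concerns the other aromatic ring, where the step of an at least 5.5-fold higher number from compound 2 to compound 4 (0.74 log units; beyond the scatter) keeps 4-bromo-3-methylphenyl on the carbonyl carbon and exchanges only chloro for methyl, so this carbonyl group alone does not carry the lower number of compound 2. On the carbonyl carbon itself, the floors of an at least 1.8-fold higher number from compound 3 to compound 4 (0.26 log units; that floor lies within the scatter) and of an at least 1.7-fold higher number from compound 1 to compound 4 (0.23 log units; that floor lies within the scatter) both lie within the scatter, so 4-bromo-3-methylphenyl is not shown to differ from 3,5-difluorophenyl or 4-nitrophenyl, although the lower number that compound 2 suggested did not appear.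

On these data alone, how far above the limit compound 4 lies remains open, as does whether chloro has the same effect with other groups on the carbonyl carbon. Also open, as far as these compounds go, is how an amine or a carboxylic acid on the carbonyl-bound aromatic ring would change this read-out.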